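A few compounds are considered here, and "the series" means these few. Any claim that something is new, unique, unknown or untested is made for them only; others in the source may bear on it.

Among the compounds with values here, in a functional assay on A549 cells (Homo sapiens) for cytotoxicity, read by MTT assay, with a stated time of 72 h (on this read-out higher numbers stand for weaker inhibition and lower numbers for stronger inhibition), compound 1 `O=C(N/N=C/c1ccc([N+](=O)[O-])cc1)Nc1cc2c(Nc3ccc(F)c(Cl)c3)ncnc2cc1O[C@H]1CCOC1` gives 31200 nM and compound 2 `COc1ccc(/C=N/NC(=O)Nc2cc3c(Nc4ccc(F)c(Cl)c4)ncnc3cc2O[C@H]2CCOC2)c(OC)c1OC` gives 25200 nM, so compound 2 stands level with its only neighbour, within the scatter. Next comes compound 3 `O=C(N/N=C/c1ccc(O)cc1)Nc1cc2c(Nc3ccc(F)c(Cl)c3)ncnc2cc1O[C@H]1CCOC1`, with 4-hydroxyphenyl in place of 2,3,4-trimethoxyphenyl on a carbon with a double bond to nitrogen. Within the data shown here, the one measured step at this place is a 1.2-fold lower number from compound 1 to compound 2 (0.09 log units; within the scatter), where 2,3,4-trimethoxyphenyl stands in place of 4-nitrophenyl. Among the measured compounds shown here, that step lies within the scatter, but a single step sets no trend, and no measured compound yet carries 4-hydroxyphenyl. No change beyond the scatter is therefore expected in this assay, and the range is kept wide. The expected size is a 1.0-fold lower number from compound 2 to compound 3 (0.00 log units; within the scatter). The estimate for compound 3 is 25000 nM, with an expected range of 10000 nM to 55000 nM.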

Compound 3, half-maximal inhibitory concentration: 1320 nM
Beside the measured number, compound 3's estimate is 19-fold (1.28 log units) above it; the whole stated range lies above it.
By their numbers in this assay, from the lowest: compound 3; then compounds 2 and 1 (each within the scatter of the next).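

In this assay the aryl group on this carbon with a double bond to nitrogen does matter: there is a 19-fold lower number from compound 2 to compound 3 (1.28 log units; beyond the scatter) on moving to 4-hydroxyphenyl, and a 24-fold lower number from compound 1 to compound 3 (1.37 log units; beyond the scatter) with hydroxy in place of nitro on an aromatic carbon. The earlier pair, 4-nitrophenyl and 2,3,4-trimethoxyphenyl, sat within the scatter of each other, so the position looked flat until compound 3, whose number lies beyond the scatter of both. Nothing available here explains the shift.

Compared with 2,3,4-trimethoxyphenyl, 4-hydroxyphenyl has fewer heavy atoms and adds a hydrogen-bond donor, and these two compounds cannot separate the two differences. As far as these compounds go, whether the hydroxy itself is needed remains open, and 4-methoxyphenyl, 4-aminophenyl or unsubstituted phenyl would be the direct comparisons.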